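Removing the terminal phosphate from the benzylsulfanyl analogue

The source may hold more compounds than are shown below. What is called first, only, known or untested is meant among the compounds shown, and "the series" means these compounds.

Compound 3 `O=c1ccn([C@@H]2O[C@H](COP(=O)(O)OP(=O)(O)O)[C@@H](O)[C@H]2O)c(SCc2ccccc2)n1` carries the only numerical result in the series: in an in vitro functional assay on 1321-N1 cells for agonist activity at P2Y purinoceptor 6 (Homo sapiens), read by scintillation proximity assay and inositol phosphate accumulation (a higher number here means that more compound is needed for the effect, a lower number that less compound is needed), compound 3 gives 6800 nM. The two other results are limits. Compound 1 `CCSc1nc(=O)ccn1[C@@H]1O[C@H](COP(=O)(O)O)[C@@H](O)[C@H]1O` gives in this assay > 100000 nM, which is a limit of the assay and not a number. Compound 2 `Nc1nc(=O)ccn1[C@@H]1O[C@H](COP(=O)(O)O)[C@@H](O)[C@H]1O` likewise gives in this assay > 100000 nM, again a limit. Going by the values given here, the one step between measured neighbours, a step that the two limits leave unreadable from compound 1 to compound 2, is therefore unreadable, and it concerns a different position from the change considered here.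

Compound 4 `O=c1ccn([C@@H]2O[C@H](COP(=O)(O)O)[C@@H](O)[C@H]2O)c(SCc2ccccc2)n1` differs from compound 3 by a hydrogen atom in place of a group of 4 heavy atoms (3 oxygen, 1 phosphorus; no ring), on an oxygen. Among the compounds with values here, no measured step addresses this change directly. What can be said is that compounds 1 and 2, which also lack the group that compound 3 carries on that oxygen, both sit at the limit (the limit of > 100000 nM in this assay, at which 2 of the 3 values shown sit), whereas compound 3, which has it, gives a readable value. On that basis the loss of the group is expected to cost activity in this assay, with the step from compound 3 to compound 4 estimated at a 22-fold higher number from compound 3 to compound 4 (1.34 log units; beyond the scatter). Compound 4 is accordingly expected to give about 150000 nM, within a range of 20000 nM to 1000000 nM, and quite possibly only a limit.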

Compound 4, half-maximal effective concentration: > 100000 nM
Compound 4 ended at the assay's limit (the forecaster's own chance of this, stated with the estimate: 75%); the middle value is on the limit's open side.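

Going by these compounds alone, with benzylsulfanyl held fixed, this is the first comparison that changes only the group on the oxygen, and in this assay the result is an at least 14-fold higher number from compound 3 to compound 4 (1.16 log units; beyond the scatter), so the readable value of compound 3 depends on that group of 4 heavy atoms (3 oxygen, 1 phosphorus). On these data alone, compound 4 stands at a limit of the assay and not at a number, so the printed size is only a bound and the full size of the change stays unknown. Benzylsulfanyl alone does not bring compound 4 to a readable value, and the steps from compound 1 and from compound 2 to compound 4 cannot be read, all three compounds sitting at the same ceiling: the limit of > 100000 nM in this assay, at which 3 of the 4 values shown sit.

Still open, as far as these compounds go, is whether ethylsulfanyl or amino in place of benzylsulfanyl would keep a readable value while the group on the oxygen is present. Also open, from the compounds shown here alone, is how far that group can be varied, for instance whether a carboxylic acid in its place or a third phosphate on the chain would give a readable value.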